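Trifluoromethyl addition on the weakest member of the series

This account rests on a few compounds, and the source may have more. Where it says the series, first, only, none or still open, it means among the compounds named here.

Measured in a functional assay on MCF7 cells (Homo sapiens) for antiproliferative activity, read by MTT assay, with a stated time of 48 h; on this read-out lower numbers stand for stronger inhibition and higher numbers for weaker inhibition:
compound 1 `Fc1ccc(C2=NN(c3nc(-c4ccc(C(F)(F)F)cc4)cs3)C(c3cccs3)C2)cc1` gives 1330 nM
compound 2 `Cc1ccc(C2=NN(c3nc(-c4ccccc4)cs3)C(c3cccs3)C2)cc1` gives 18600 nM

Compound 2 stands highest of the two numbers; compound 1 sits well below it, a gap beyond the scatter. Compound 3 `Cc1ccc(C2=NN(c3nc(-c4ccc(C(F)(F)F)cc4)cs3)C(c3cccs3)C2)cc1` differs from compound 2 by trifluoromethyl in place of hydrogen on an aromatic carbon, para to a large group. Within the data shown here, no step between measured compounds isolates this change, so the direction rests on compound 1 alone, which carries the same group and gives 1330 nM. Compound 3 is expected to move down by a 7.4-fold lower number from compound 2 to compound 3 (0.87 log units; beyond the scatter), toward compound 1. Compound 3 is estimated at 2500 nM, within 800 nM to 8000 nM.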

Compound 3, half-maximal inhibitory concentration: 31500 nM
Beside the measured number, compound 3's estimate is 13-fold (1.10 log units) below it, outside the stated range (above it).
By their numbers in this assay, from the lowest: compound 1; then compounds 2 and 3 (each within the scatter of the next).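

In this assay, trifluoromethyl in place of hydrogen, para to a large group, gives (a 1.7-fold higher number from compound 2 to compound 3 (0.23 log units; within the scatter)), so with the methyl kept, this change brings no gain. With trifluoromethyl kept, methyl in place of fluoro gives (a 24-fold higher number from compound 1 to compound 3 (1.37 log units; beyond the scatter)), so the low number of compound 1 goes with the fluoro and not with trifluoromethyl alone. No data on hand bear on the reason for either step.

From the compounds shown here alone, whether trifluoromethyl has any effect with fluoro in place of the methyl remains open. So does how an amine or a carboxylic acid would read at this position.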